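The source may hold more compounds than are shown below. What is called first, only, known or untested is meant among the compounds shown, and "the series" means these compounds.

Measured compounds:
compound 1 `c1ccc(-c2ccncc2)c(OCC2=NCCN2)c1`; in a functional assay for activation of Alpha-1A adrenergic receptor (Homo sapiens), read by calcium flux (on this read-out lower numbers stand for an effect already at smaller amounts and higher numbers for an effect only at larger amounts of compound), compound 1 gives only a limit, < 100000 nM.
compound 2 `c1c[nH]c(-c2ccccc2OCC2=NCCN2)c1`; in this assay compound 2 gives 1.26 nM.
compound 3 `c1ccc(-c2ccsc2)c(OCC2=NCCN2)c1`; in this assay compound 3 gives 0.251 nM.

Compound 3 holds the lowest of the two readable numbers, compound 2 being nearest; the step of a 5.0-fold lower number from compound 2 to compound 3 (0.70 log units; beyond the scatter) is modest but beyond the scatter. The steps from compound 1 stay unreadable because of the limit of < 100000 nM in this assay, at which 1 of the 3 values shown sits. Compound 4 `c1ccc(-c2ccns2)c(OCC2=NCCN2)c1` is not yet measured; it differs from compound 3 by 1,2-thiazol-5-yl in place of thiophen-3-yl on an aromatic carbon. Within the data shown here, only the step of a 5.0-fold lower number from compound 2 to compound 3 (0.70 log units; beyond the scatter) bears on it, a swap of the five-membered ring that shifted the number modestly; a second hetero atom entering that ring is expected to raise the number modestly, as a 6.0-fold higher number from compound 3 to compound 4 (0.78 log units; beyond the scatter). For compound 4 the expected value in this assay is 1.5 nM, with a range from 0.25 nM to 10 nM.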

Compound 4, half-maximal effective concentration: 5.01 nM
Compound 4: middle estimate off by 3.3-fold (0.52 log units), on the low side, and the stated range covers the measured number.
By their numbers in this assay, from the lowest: compound 3; then compound 2; then compound 4.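

In this assay, this place on the aromatic ring proves sensitive to a single ring atom: with the heavy-atom count unchanged, 1,2-thiazol-5-yl in place of thiophen-3-yl gives a 20-fold higher number from compound 3 to compound 4 (1.30 log units; beyond the scatter). The spread among five-membered rings is therefore wider than the earlier pair showed, and 1,2-thiazol-5-yl in place of 1H-pyrrol-2-yl gives a 4.0-fold higher number from compound 2 to compound 4 (0.60 log units; beyond the scatter). The steps from compound 1 cannot be read, as compound 1 gives only a limit: the limit of < 100000 nM in this assay, at which 1 of the 4 values shown sits.

Still open, as far as these compounds go, is how a plain phenyl ring would read at this place. Also open, from the compounds shown here alone, is whether an aminomethyl group on the thiophen-3-yl ring would be tolerated.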